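Methyl for Methoxy: What to Expect of Compound 4

The source may report more compounds than this note shows. Statements on the series, on what has been measured and on what is new or still open speak of the compounds shown alone.

The measured compounds, all tested in a functional assay on the whole organism (strain L.) for inhibition, with Echinochloa crus-galli as the target, with a stated time of 72 h, tested at 10 mg/L; on this read-out higher numbers stand for more inhibition of growth at the one concentration tested and lower numbers for less inhibition of growth:
- compound 1, `Cc1onc(-c2ccc(Cl)cc2Cl)c1C(=O)/N=c1/nc2nc(Cl)cc(C)n2s1`, gives 25.8%
- compound 2, `COc1cc(OC)nc(NC(=S)NC(=O)c2c(-c3ccc(Cl)cc3Cl)noc2C)n1`, gives 21.8%
- compound 3, `COc1cc(Cl)nc2n/c(=N/C(=O)c3c(-c4ccc(Cl)cc4Cl)noc3C)sn12`, gives 10.8%

Compound 1 and compound 3 share a core and differ in one place: methyl in place of methoxy on an aromatic carbon. That single swap makes the step of a number 15 percentage points higher from compound 3 to compound 1 (beyond the scatter), so in this pair the methyl gave clearly more growth inhibition than the methoxy.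

Compound 2 stands apart from compound 3: the difference between the two cores is not broken down here. Compound 2 and compound 3 lie beyond the scatter of each other, while compound 2 and compound 1 lie within it.

The unmeasured compound 4, `COc1cc(C)nc(NC(=S)NC(=O)c2c(-c3ccc(Cl)cc3Cl)noc2C)n1`, differs from compound 2 by methyl in place of methoxy on an aromatic carbon. Among the measured compounds shown here, this is the same kind of change as the one from compound 3 to compound 1, but not the same: there the methyl entered on a ring that is part of a fused or bridged system of two rings, ortho to a fused ring and meta to a chloro group; here it enters on a ring that is not fused, meta to a large group and meta to a methoxy group. For the measured compounds named here, because the only comparable pair gave a number 15 percentage points higher from compound 3 to compound 1 (beyond the scatter), the step from compound 2 to compound 4 is expected to be in the same direction, though smaller, as it rests on a single pair on a different core. The expected step for compound 4 is a number 9.2 percentage points higher from compound 2 to compound 4 (within the scatter). Compound 4 is therefore estimated at 31%, with a range from 16% to 46%.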

Compound 4, percent growth inhibition at one concentration: 12.3%
Compound 4: the middle estimate sits 18.7 percentage points above what was measured; the measured number lies below the stated range.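

Putting methyl in place of methoxy gives a step of a number 9.5 percentage points lower from compound 2 to compound 4 (within the scatter), so on this core the change leaves no difference from compound 2 that can be told from ordinary scatter in this assay. Set beside the earlier pair, the same change does not behave alike on the two cores: the same change on two cores in this assay, a number 15 percentage points higher (beyond the scatter) from compound 3 to compound 1 and a number 9.5 percentage points lower (within the scatter) from compound 2 to compound 4, 24.5 percentage points apart, beyond the scatter of two such steps. Among the compounds shown here, this shows that the gain seen on going to compound 1 cannot simply be carried over to the core of compound 2, but with only one pair on each core it does not show why the cores differ, nor how the change would behave on a third core.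

The compounds shown leave open what other groups would do at this place on the pyrimidine ring, such as an amine like dimethylamino, or a longer chain like ethoxy or propoxy in place of methoxy. They also leave open whether a second pair on each core would repeat this split, since every comparison here rests on a single swap read at one concentration.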